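A few compounds are considered here, and "the series" means these few. Any claim that something is new, unique, unknown or untested is made for them only; others in the source may bear on it.

The measured compounds:
- compound 1 `O=c1cc(Cn2cc(CCCCl)nn2)c2ccc(O)cc2o1` gives 59800 nM in a functional assay on SW-620 cells (Homo sapiens) for inhibition, read by MTT assay, with a stated time of 72 h; on this read-out lower numbers stand for stronger inhibition and higher numbers for weaker inhibition
- compound 2 `O=c1cc(Cn2cc(CNS(=O)(=O)c3ccc(Cl)cc3)nn2)c2ccc(O)cc2o1`, for which this assay reports only a limit, > 100000 nM

In this assay compound 1 gives 59800 nM. For compound 2 no number is known, only the limit > 100000 nM, which is the limit of > 100000 nM in this assay, at which 1 of the 2 values shown sits. Compound 2 therefore stands at the upper edge of what this assay reports, and its true value could lie anywhere at or beyond that edge.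

Compound 3 `O=c1cc(Cn2cc(CNS(=O)(=O)c3ccc(F)cc3Cl)nn2)c2ccc(O)cc2o1` differs from compound 2 in one place: 2-chloro-4-fluorophenyl in place of 4-chlorophenyl on a sulfonyl sulfur. Going by the values given here, no step between two measured compounds matches this change, so there is nothing here to say how adding a fluorine and moving the chlorine on this ring shifts the read-out. Given that compound 2 already reached the limit > 100000 nM, the step from compound 2 to compound 3 is expected to stay within the scatter, a step that the limit leaves unreadable from compound 2 to compound 3. Compound 3 is accordingly estimated at 110000 nM, with a range from 40000 nM to 300000 nM, and a fair chance that this assay again reports only a limit.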

Compound 3, half-maximal inhibitory concentration: > 100000 nM
Compound 3 was reported as a limit; the forecaster's own chance of this, stated with the estimate: 60%; the middle value lies beyond the limit too.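

In this assay, compound 2 and compound 3 are each reported only as a limit, not as a number, so no step between them can be read: the limit of > 100000 nM in this assay, at which 2 of the 3 values shown sit.

The compounds shown leave open how far past that limit each compound truly lies, and whether 2-chloro-4-fluorophenyl in place of 4-chlorophenyl on a sulfonyl sulfur changes the read-out at all.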